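Plasma exposure notes on a thioamide and thioimidate pair

The source may hold more compounds than are shown below. What is called first, only, known or untested is meant among the compounds shown, and "the series" means these compounds.

Measured so far:
compound 1 `S=C(NCc1ccccc1)c1cccs1` — 310 nM
compound 2 `COc1ccc(C(=N)SCc2ccccc2)cc1` — 7200 nM

In an ADME assay for pharmacokinetics, in phosphate buffer, with a stated time of 30 min, at pH 7.4, tested at 1 mM, at a dose of 1 mM, in the presence of a further agent that is not named here (a higher number here means more compound in the circulation at the dose given, a lower number less compound in the circulation), compound 2 holds the higher of the two numbers, and compound 1 holds the lower; the gap between them is beyond the scatter, but the two structures differ in several places, so no single change can be credited.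

Compound 3 `N=C(SCc1ccccc1)c1ccc(O)cc1` remains to be measured. It differs from compound 2 by hydrogen in place of methyl on an oxygen on an aromatic ring. Going by the values given here, no measured pair shows this change on its own, so its effect here is unknown. A modest fall is expected, near the edge of the scatter. Compound 3 is estimated at 3000 nM with a range of 1000 nM to 9000 nM. The expected step is a 2.4-fold lower number from compound 2 to compound 3 (0.38 log units; beyond the scatter).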

Compound 3, maximal plasma concentration in the ADME assay: 6800 nM
Estimate against measurement, compound 3: 2.3-fold (0.36 log units) below; the range from low to high includes it.
By their numbers in the ADME assay, from the lowest: compound 1; then compounds 3 and 2 (each within the scatter of the next).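

In the ADME assay, hydrogen in place of methyl on an oxygen on an aromatic ring gives a 1.1-fold lower number from compound 2 to compound 3 (0.02 log units; within the scatter), so maximal plasma concentration holds through this change. In a physicochemical assay for pharmacokinetics, in phosphate buffer, with a stated time of 30 min, at pH 7.4, tested at 1 mM, in the absence of a further agent (on this read-out higher numbers stand for a longer-lived compound and lower numbers for a shorter-lived compound), compound 2 gives 0.289 h and compound 3 gives 0.088 h, and the same change there gives a 3.3-fold lower number from compound 2 to compound 3 (0.52 log units; beyond the scatter). Going by these compounds alone, this first matched pair therefore separates the two read-outs at this position, which the earlier compounds, differing in several places, could not show.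

Going by these compounds, whether an amine in place of the hydroxy, or a longer chain on that oxygen, would follow either read-out stays open. With a single pair, the reach of this change to the core of compound 1 is also unknown.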